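Dropping the Benzyloxycarbonyl Group: Expected Gain in Tail Flick

The compounds below may be only part of what the source reports. "The series", "measured", "known", "first", "only" and "open" are said of these compounds alone.

Measured in a functional assay on the whole organism (Tail, strain ICR) with Mus musculus as the target, in the tail flick test, with a stated time of 90 min, at a dose of 25 umol/kg by the oral route; on this read-out higher numbers stand for a stronger effect at the one dose given and lower numbers for a weaker effect:
compound 1 `C[C@H](NC(=O)CN(c1nc(Cl)nc2[nH]cnc12)C1CC1)C(=O)OCc1ccccc1` gives 44.2%;
compound 2 `O=C(CN(c1nc(Cl)nc2[nH]cnc12)C1CC1)N[C@@H](CC(=O)OCc1ccccc1)C(=O)OCc1ccccc1` gives 15.6%;
compound 3 `O=C(CN(c1ncnc2c1ncn2C1CCCCO1)C1CC1)N[C@@H](CC(=O)OCc1ccccc1)C(=O)OCc1ccccc1` gives 25.1%.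

Compound 4 `C[C@H](NC(=O)CN(c1ncnc2c1ncn2C1CCCCO1)C1CC1)C(=O)OCc1ccccc1` awaits measurement in this assay. Compound 4 differs from compound 3 by hydrogen in place of benzyloxycarbonyl on a saturated chain carbon, two bonds along the chain from an amide-type nitrogen and a carbonyl carbon. The same change, (hydrogen in place of benzyloxycarbonyl on a saturated chain carbon, two bonds along the chain from an amide-type nitrogen and a carbonyl carbon), separates compound 2 from compound 1 and there gave a number 28.6 percentage points higher from compound 2 to compound 1 (beyond the scatter). The difference between the cores of compound 2 and compound 3 is not broken down here; the values of compound 3 and compound 2 lie within the scatter of each other. For the measured compounds named here, only one measured example of this change exists, so the expectation carries real uncertainty, and on a different core the gain may be smaller. The expected step is a number 19.9 percentage points higher from compound 3 to compound 4 (beyond the scatter), resting on the measured step of a number 28.6 percentage points higher from compound 2 to compound 1 (beyond the scatter). Compound 4 is estimated at 45%, with a likely range from 30% to 62%.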

Compound 4, a percentage reported as activity, at one dose (the size of the read-out at that dose, not a potency): 32.1%
Compound 4: middle estimate off by 12.9 percentage points, on the high side, within the range that was stated.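

Removing the benzyloxycarbonyl group gives, in this assay, a number 7 percentage points higher from compound 3 to compound 4 (within the scatter) and so brings no clear gain on this core. The change therefore did not carry over at its earlier size, and the two steps differ by more than repeat measurements would explain: the same change on two cores in this assay, a number 28.6 percentage points higher (beyond the scatter) from compound 2 to compound 1 and a number 7 percentage points higher (within the scatter) from compound 3 to compound 4, 21.6 percentage points apart, beyond the scatter of two such steps.
This shows that the effect of the change depends on the core that carries it, but it does not show which feature of the cores is responsible, and two pairs are too few to support a general rule.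

The compounds shown leave open how the change would behave with a carboxylic acid in place of the remaining benzyl ester. They also leave open whether a longer chain in place of the methyl would alter the picture on either core.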